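Aryl urea changes on a shared core: compound 4

The compounds below may be only part of what the source reports. "The series", "measured", "known", "first", "only" and "open" are said of these compounds alone.

Values in a functional assay on T47D cells (Homo sapiens) for antiproliferative activity, read by MTT assay, with a stated time of 48 h (on this read-out lower numbers stand for stronger inhibition and higher numbers for weaker inhibition), so far:
- compound 1 `O=C(Nc1cccc(Cl)c1)Nc1nnc(Sc2ncnc3scc(-c4ccncc4)c23)s1`: 43900 nM
- compound 2 `O=C(Nc1cccc(C(F)(F)F)c1)Nc1nnc(Sc2ncnc3scc(-c4ccncc4)c23)s1`: 45100 nM
- compound 3 `COc1ccc(NC(=O)Nc2nnc(Sc3ncnc4scc(-c5ccncc5)c34)s2)cc1`: a limit only, > 100000 nM

Compound 2 holds the highest of the two numbers obtained, with compound 1 nearest; the step of a 1.0-fold higher number from compound 1 to compound 2 (0.01 log units; within the scatter) lies within the scatter, so chloro and trifluoromethyl on the 3-chlorophenyl position read alike. Compound 3 returns only a limit (the limit of > 100000 nM in this assay, at which 1 of the 3 values shown sits).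

Compound 4 `O=C(Nc1ccc(Cl)c(Cl)c1)Nc1nnc(Sc2ncnc3scc(-c4ccncc4)c23)s1` differs from compound 2 as follows: 3,4-dichlorophenyl in place of 3-(trifluoromethyl)phenyl on an amide-type nitrogen. For the measured compounds named here, two measured steps bear on this. The step of a 1.0-fold higher number from compound 1 to compound 2 (0.01 log units; within the scatter) shows the first substituent matters little. The steps of an at least 2.2-fold higher number from compound 1 to compound 3 (0.35 log units; beyond the scatter) and an at least 2.2-fold higher number from compound 2 to compound 3 (0.34 log units; beyond the scatter) show that moving to 4-methoxyphenyl weakens activity, so the aryl group is not inert. Going by the values given here, no measured step covers adding a second chloro. Compound 4 keeps the chloro of compound 1 and is therefore expected to stay close to compound 2, with a 1.5-fold lower number from compound 2 to compound 4 (0.18 log units; within the scatter) not beyond the scatter. The estimate for compound 4 in this assay is 30000 nM, expected between 12000 nM and 80000 nM.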

Compound 4, half-maximal inhibitory concentration: 14600 nM
Compound 4: the middle estimate sits 2.1-fold (0.31 log units) above what was measured; measured number inside the range.
By their numbers in this assay, from the lowest: compound 4; then compounds 1 and 2 (each within the scatter of the next). At a limit, above all of these: compound 3.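

In this assay, for the compounds shown here, the second chloro is the first change on this aryl group to move the number beyond the scatter among the halogen-bearing ureas: a 3.0-fold lower number from compound 1 to compound 4 (0.48 log units; beyond the scatter) for chloro in place of hydrogen on an aromatic carbon. Against the trifluoromethyl analogue the picture is the same, with a 3.1-fold lower number from compound 2 to compound 4 (0.49 log units; beyond the scatter), so 3,4-dichlorophenyl separates from 3-(trifluoromethyl)phenyl although 3-chlorophenyl did not, and compound 4 holds the lowest number of the four. The step of an at least 6.8-fold lower number from compound 3 to compound 4 (0.83 log units; beyond the scatter) starts from a limit and not from a number: the limit of > 100000 nM in this assay, at which 1 of the 4 values shown sits.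

Why the second chloro lowers the number cannot be read from these compounds, and the effect of that chloro without the first stays unknown. Also open, on these data alone, is how a bromo, a nitrile or a dimethylamino group on the phenyl ring would read.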